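Alpha-methyl analogue of a hydroxamic acid

A few compounds are considered here, and "the series" means these few. Any claim that something is new, unique, unknown or untested is made for them only; others in the source may bear on it.

Measured compounds:
compound 1 `O=C(NO)C(Cc1ccccc1)C(=O)NCc1ccc(F)cc1`: 0.8 h
compound 2 `CN(O)C(=O)C(Cc1ccccc1)C(=O)NCc1ccc(F)cc1`: 0.5 h
compound 3 `CC1(C)ON=C(C(Cc2ccccc2)C(=O)NCc2ccc(F)cc2)O1`: 1 h

In an ADME assay on a cell-free system (plasma, Rattus norvegicus, strain Sprague-Dawley) for metabolic stability, read by LC-MS, tested at 10 uM (on this read-out lower numbers stand for a shorter-lived compound and higher numbers for a longer-lived compound), compound 1 gives 0.8 h, the second highest of the three numbers. Its nearest neighbour is compound 3, and the step from a 1.3-fold higher number from compound 1 to compound 3 (0.10 log units; within the scatter) is within the scatter, as is the step of a 1.6-fold lower number from compound 1 to compound 2 (0.20 log units; within the scatter). The step of a 2.0-fold higher number from compound 2 to compound 3 (0.30 log units; within the scatter) is likewise within the scatter, so the three measured compounds cannot be told apart in this assay.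

Compound 4 `CC(Cc1ccccc1)(C(=O)NO)C(=O)NCc1ccc(F)cc1` differs from compound 1 by methyl in place of hydrogen on a saturated chain carbon bound to two carbonyl carbons and a saturated chain carbon. Going by the values given here, none of the measured steps touches this position: all three concern the group on the saturated chain carbon bound to a carbonyl carbon, not the chain carbon itself. Among the compounds with values here, no measured step therefore bears directly on the change, and the measured steps that exist are all within the scatter.

With no guide beyond that, compound 4 is expected to give about 1 h in this assay, with a range from 0.4 h to 2.5 h, a step from a 1.3-fold higher number from compound 1 to compound 4 (0.10 log units; within the scatter) that is expected to stay within the scatter.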

Compound 4, half-life: 3.6 h
Beside the measured number, compound 4's estimate is 3.6-fold (0.56 log units) below it, outside the stated range (above it).
By their numbers in this assay, from the lowest: compounds 2, 1 and 3 (each within the scatter of the next); then compound 4.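

In this assay, going by these compounds alone, methyl in place of hydrogen on a saturated chain carbon bound to two carbonyl carbons and a saturated chain carbon gives a 4.5-fold higher number from compound 1 to compound 4 (0.65 log units; beyond the scatter) and is the only step here beyond the scatter. The earlier steps shown here all changed the group on that carbon and left compound 1, compound 2 and compound 3 within the scatter of one another, whereas this result shows that a single methyl on the chain carbon itself can separate two compounds on half-life. Nothing available gives a reason for this step.

The compounds shown leave open whether an ethyl group or a fluorine atom at the same place would give a similar step. They also leave open whether the same methyl would have a like effect on compound 2 or compound 3.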